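The source may report more compounds than this note shows. Statements on the series, on what has been measured and on what is new or still open speak of the compounds shown alone.

Measured compounds:
Compound 1 `COc1ccc(C2CC(=O)C=CO2)cc1` gives 193 uM in a functional assay on NCI-H460 cells (Homo sapiens) for inhibition, read by sulforhodamine B assay, with a stated time of 48 h; a lower number here means a stronger inhibitor of growth, a higher number a weaker inhibitor of growth.
Compound 2 `COc1ccc(C2CC(=O)C(Br)=CO2)cc1` gives 118 uM in this assay.

Among the measured compounds shown here, with only two compounds measured, the standing of compound 2 rests on a single comparison: the step of a 1.6-fold lower number from compound 1 to compound 2 (0.21 log units; within the scatter) is within the scatter, so on these numbers compound 2 cannot be told apart from compound 1.

Compound 3 `COc1ccc(C2CC(=O)C(I)=CO2)cc1` is the next compound. It differs from compound 2 as follows: iodo in place of bromo on a double-bonded ring carbon. For the measured compounds named here, the one measured step, a 1.6-fold lower number from compound 1 to compound 2 (0.21 log units; within the scatter), concerns a bromo entering where hydrogen stood and is the only guide available; it does not directly cover one halogen replacing another, and it was small, within the scatter. Nothing in the measured data suggests that swapping bromo for iodo at the same place should move the number far. The step from compound 2 to compound 3 is therefore expected to be a 1.2-fold lower number from compound 2 to compound 3 (0.07 log units; within the scatter), staying within the scatter. Compound 3 is estimated at 100 uM in this assay, with a range from 45 uM to 220 uM.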

Compound 3, concentration for growth inhibition (reported as GI): 74.6 uM
Compound 3: the middle estimate sits 1.3-fold (0.13 log units) above what was measured; low and high end bracket the measured number.
By their numbers in this assay, from the lowest: compounds 3, 2 and 1 (each within the scatter of the next, the first and the last beyond it).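

Replacing bromo with iodo on this double-bonded ring carbon, two ring bonds from the ring oxygen, gives a 1.6-fold lower number from compound 2 to compound 3 (0.20 log units; within the scatter) in this assay and so these two halogens cannot be told apart at this position. Among the compounds shown here, measured against hydrogen, however, iodo gives a 2.6-fold lower number from compound 1 to compound 3 (0.41 log units; beyond the scatter) and this is the first step at this position to pass the usual scatter, though only modestly, whereas the bromo step, a 1.6-fold lower number from compound 1 to compound 2 (0.21 log units; within the scatter) stayed inside it. A substituent at this place can therefore shift the growth-inhibition number measurably, but the shift is small, and compound 3 still needs 74.6 uM to register in this test; no accompanying measurement offers any explanation of the shift.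

On these data alone, whether a group other than a halogen on the same ring carbon, such as a methyl, a nitrile or an amine, would move the number further in either direction stays open, as does the place of chloro and fluoro alongside bromo and iodo. Also open, as far as these compounds go, is how much the number depends on the group of 8 heavy atoms on the ring, which stays the same in all three compounds.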